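Ethyl on a Pyrrole Core: Expected Response for Compound 4

This account rests on a few compounds, and the source may have more. Where it says the series, first, only, none or still open, it means among the compounds named here.

Compound 1 `CCn1ncnc1-c1ccccc1NCC1=NCCN1` is the starting point. In a functional assay with Alpha-1B adrenergic receptor (Homo sapiens) as the target, read by calcium flux (on this read-out higher numbers stand for larger maximal responses and lower numbers for smaller maximal responses), compound 1 gives 94%. Compound 2 `CC(C)n1ncnc1-c1ccccc1NCC1=NCCN1` carries one more carbon on its side chain; the change is methyl in place of hydrogen on a saturated chain carbon bound to an aromatic nitrogen and a saturated chain carbon, and in this assay compound 2 gives 0%, a step of a number 94 percentage points lower from compound 1 to compound 2 (beyond the scatter).

Compound 3 `Cn1cccc1-c1ccccc1NCC1=NCCN1` rests on a different core; the difference between the two cores is not broken down here. In this assay compound 3 gives 0%, level with compound 2 at the digits shown.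

Compound 4 `CCn1cccc1-c1ccccc1NCC1=NCCN1` is not yet measured. It differs from compound 3 by methyl in place of hydrogen on a saturated chain carbon bound to an aromatic nitrogen. Among the compounds with values here, this is the same kind of change as the one from compound 1 to compound 2, but around the place it differs: in the earlier pair the saturated chain carbon was bound to an aromatic nitrogen and a saturated chain carbon, here only to an aromatic nitrogen.

The earlier step removed the whole response, yet compound 3 already sits at the bottom, so the expected step is a number 15 percentage points higher from compound 3 to compound 4 (beyond the scatter), small and uncertain. In this assay compound 4 is estimated to give 15%, with a range from 0% to 55%.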

Compound 4, largest response reached (reported as maximal response), in percent of the reference or control that the assay uses: 0%
Compound 4: middle estimate off by 15 percentage points, on the high side, within the range that was stated.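

In this assay the added methyl gives no change at the digits printed from compound 3 to compound 4 (within the scatter), so the large loss seen on the core of compound 1 does not reappear in numbers on this core: the same change on two cores in this assay, a number 94 percentage points lower (beyond the scatter) from compound 1 to compound 2 and no change at the digits printed (within the scatter) from compound 3 to compound 4, 94 percentage points apart, beyond the scatter of two such steps

This does not show that the change is harmless on the second core, since compound 3 gives 0% and a response that is already absent has nothing left to lose. Within the data shown here, with only two pairs, which also start from different chains (ethyl in one, methyl in the other), the result shows that the step cannot simply be copied from one core to the other, but it gives no rule for when it would carry over.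

The compounds shown leave open how a methyl in place of the ethyl of compound 1 would read on the core of compound 1. They also leave open whether any group on the second core, such as a hydrogen or a longer chain like propyl, would bring a response back.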